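Trifluoroacetyl for methylsulfonyl on the piperidine nitrogen

The source may hold more compounds than are shown below. What is called first, only, known or untested is meant among the compounds shown, and "the series" means these compounds.

Of the compounds shown here, three have been tested in an ADME assay on TZM cells (Homo sapiens) for cytotoxicity, with a stated time of 1 days; on this read-out higher numbers stand for lower toxicity in this test and lower numbers for higher toxicity in this test. Compound 1 `Cc1cc(C#N)cc(C)c1Oc1nc(Nc2ccc(C#N)cc2)ncc1/C=C/C(N)=O` carries a free amide hydrogen; in this assay compound 1 gives only a limit, > 243 nM. Compound 2 `C#CCNC(=O)/C=C/c1cnc(Nc2ccc(C#N)cc2)nc1Oc1c(C)cc(C#N)cc1C` has the propargyl group on the amide nitrogen; for compound 2 the result is again a limit, > 222 nM. Compound 3 `Cc1cc(C#N)cc(C)c1Oc1nc(Nc2ccc(C#N)cc2)ncc1/C=C/C(=O)NC1CCN(S(C)(=O)=O)CC1` bears the 1-(methylsulfonyl)piperidin-4-yl group on that nitrogen; compound 3 likewise reaches only a limit, > 175 nM. Compound 3 therefore stands at one of three limits, with no numerical value in the set; the comparisons a step that the two limits leave unreadable from compound 1 to compound 2, a step that the two limits leave unreadable from compound 1 to compound 3 and a step that the two limits leave unreadable from compound 2 to compound 3 are all unreadable, as the limit of > 175 nM in this assay, at which 1 of the 3 values shown sits, the limit of > 222 nM in this assay, at which 1 of the 3 values shown sits, and the limit of > 243 nM in this assay, at which 1 of the 3 values shown sits, record.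

Compound 4 `Cc1cc(C#N)cc(C)c1Oc1nc(Nc2ccc(C#N)cc2)ncc1/C=C/C(=O)NC1CCN(C(=O)C(F)(F)F)CC1` differs from compound 3 by (trifluoromethyl)carbonyl in place of methylsulfonyl on an amine nitrogen in a ring. Going by the values given here, none of the measured steps touches this ring nitrogen; all three concern the amide nitrogen, and all three are unreadable, so they set no expectation of a readable step in either direction. Compound 4 is thus expected to behave like compound 3 and return a limit as well, with a step that the limit leaves unreadable from compound 3 to compound 4 as the estimated step. The estimate for compound 4 is 230 nM, within 110 nM to 2500 nM.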

Compound 4, half-maximal cytotoxic concentration: > 170 nM
Compound 4 ended at the assay's limit; the forecaster's own chance of this, stated with the estimate: 85%; the middle value does not contradict the limit.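

In this assay compound 4 gives only a limit, > 170 nM. Going by these compounds alone, compound 1, compound 2, compound 3 and compound 4 all end at limits, so no step among them can be read. The compounds shown leave open where any true value lies, and whether (trifluoromethyl)carbonyl and methylsulfonyl on the ring nitrogen differ in this read-out at all.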